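Furan-2-yl for Naphthalen-2-yl: Expecting Compound 4

The source may hold more compounds than are shown below. What is called first, only, known or untested is meant among the compounds shown, and "the series" means these compounds.

Measured in an ADME assay on NIH3T3 cells (Homo sapiens) for cytotoxicity, read by sulforhodamine B assay, with a stated time of 48 h (on this read-out lower numbers stand for stronger inhibition and higher numbers for weaker inhibition), so far:
Compound 1 `CC(=O)OC[C@H]1O[C@@H](n2cc(CN3C(=O)/C(=C\c4ccccc4)c4ccccc43)nn2)[C@H](OC(C)=O)[C@@H](OC(C)=O)[C@@H]1OC(C)=O` gives 22800 nM.
Compound 2 `COc1ccc(/C=C2\C(=O)N(Cc3cn([C@@H]4O[C@H](COC(C)=O)[C@@H](OC(C)=O)[C@H](OC(C)=O)[C@H]4OC(C)=O)nn3)c3ccccc32)cc1OC` reaches only the assay limit > 100000 nM.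
Compound 3 `CC(=O)OC[C@H]1O[C@@H](n2cc(CN3C(=O)/C(=C\c4ccc5ccccc5c4)c4ccccc43)nn2)[C@H](OC(C)=O)[C@@H](OC(C)=O)[C@@H]1OC(C)=O` gives 80000 nM.

Compound 3 holds the highest of the two real numbers; its nearest neighbour is compound 1, with a 3.5-fold higher number from compound 1 to compound 3 (0.55 log units; beyond the scatter). Compound 2 sits at a limit (the limit of > 100000 nM in this assay, at which 1 of the 3 values shown sits), so the comparison an at least 1.2-fold lower number from compound 2 to compound 3 (0.09 log units; that floor lies within the scatter) says little.

Compound 4 `CC(=O)OC[C@H]1O[C@@H](n2cc(CN3C(=O)/C(=C\c4ccco4)c4ccccc43)nn2)[C@H](OC(C)=O)[C@@H](OC(C)=O)[C@@H]1OC(C)=O` has not been measured. It differs from compound 3 in one place: furan-2-yl in place of naphthalen-2-yl on a double-bonded chain carbon bound to a double-bonded ring carbon.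

Within the data shown here, the steps that bear on this change all touch the same position. Replacing phenyl by naphthalen-2-yl gave a 3.5-fold higher number from compound 1 to compound 3 (0.55 log units; beyond the scatter), and replacing phenyl by 3,4-dimethoxyphenyl gave an at least 4.3-fold higher number from compound 1 to compound 2 (0.64 log units; beyond the scatter). Phenyl, the smallest group tried, gave the lowest number. Furan-2-yl is a single five-membered ring, closer in size to phenyl than to naphthalen-2-yl, so in this assay compound 4 is expected to move back toward the number of compound 1, a step of about a 2.7-fold lower number from compound 3 to compound 4 (0.43 log units; beyond the scatter). Compound 4 is therefore estimated at 30000 nM, with a plausible range from 10000 nM to 100000 nM.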

Compound 4, half-maximal inhibitory concentration: 13300 nM
Compound 4: the middle estimate sits 2.3-fold (0.35 log units) above what was measured, and the stated range covers the measured number.
By their numbers in this assay, from the lowest: compounds 4 and 1 (each within the scatter of the next); then compound 3. At a limit, above all of these: compound 2.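

In this assay, the place on a double-bonded chain carbon bound to a double-bonded ring carbon now shows that the rise seen with naphthalen-2-yl can be undone by a smaller ring that holds an oxygen: a 6.0-fold lower number from compound 3 to compound 4 (0.78 log units; beyond the scatter). Until now every replacement of phenyl had given a higher number, but furan-2-yl does not, and with a 1.7-fold lower number from compound 1 to compound 4 (0.23 log units; within the scatter) the two groups cannot be told apart in this read-out. Against 3,4-dimethoxyphenyl the step is an at least 7.5-fold lower number from compound 2 to compound 4 (0.87 log units; beyond the scatter), and compound 2 counts as a limit of the assay rather than a number: the limit of > 100000 nM in this assay, at which 1 of the 4 values shown sits.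

Furan-2-yl brings a five-membered ring and an oxygen in a single change, and the compounds shown do not separate these two differences from phenyl. On these data alone, how thiophen-2-yl, which carries sulfur where furan-2-yl carries oxygen, would behave at this place remains open, as does whether any group here can give a number clearly lower than those of compound 1 and compound 4.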